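This account rests on a few compounds, and the source may have more. Where it says the series, first, only, none or still open, it means among the compounds named here.

Compounds measured in a functional assay on NCI-H292 cells (Homo sapiens) for antiproliferative activity; on this read-out lower numbers stand for stronger inhibition and higher numbers for weaker inhibition:
Compound 1, `COc1cccc(N2C(=O)N/C(=C\c3ccc(O)cc3)C2=O)c1`, sits at a limit, > 200000 nM.
Compound 2, `O=C1N/C(=C\c2ccc(O)cc2)C(=O)N1c1cccc(I)c1`, likewise sits at a limit, > 200000 nM.
Compound 3, `O=C(NCc1ccccc1)c1cccc(N2C(=O)N/C(=C\c3ccc(O)cc3)C2=O)c1`, gives 23500 nM.

Going by the values given here, compound 3 thus holds the only real number in this assay; the other two compounds stop at the limit of > 200000 nM in this assay, at which 2 of the 3 values shown sit. Both steps toward it, an at least 8.5-fold lower number from compound 1 to compound 3 (0.92 log units; beyond the scatter) and an at least 8.5-fold lower number from compound 2 to compound 3 (0.92 log units; beyond the scatter), were at least modest improvements. Compound 4, `O=C(c1cccc(N2C(=O)N/C(=C\c3ccc(O)cc3)C2=O)c1)N1CCCC1`, differs from compound 3 by pyrrolidin-1-yl in place of benzylamino on a carbonyl carbon. Among the compounds with values here, no measured step touches this change directly; the two steps above only show that the benzylcarbamoyl group did better than methoxy or iodo, not which part of it mattered. The amide hydrogen and the aromatic ring both leave, so compound 4 is expected to lose ground, with a 2.6-fold higher number from compound 3 to compound 4 (0.41 log units; beyond the scatter) as the estimated step. Compound 4 is accordingly estimated at 60000 nM, between 15000 nM and 200000 nM.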

Compound 4, half-maximal inhibitory concentration: > 200000 nM
Compound 4: no number, only a limit (the forecaster's own chance of this, stated with the estimate: 30%); middle value at least 3.3-fold (0.52 log units) away from the limit.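

In this assay, pyrrolidin-1-yl in place of benzylamino on a carbonyl carbon brings an at least 8.5-fold higher number from compound 3 to compound 4 (0.92 log units; beyond the scatter). A carbonyl at this place is thus not enough on its own, and the activity of this series depends on the benzylamino part, with compound 4 now also sitting at a limit: the limit of > 200000 nM in this assay, at which 3 of the 4 values shown sit. The steps from compound 1 and from compound 2 to compound 4 join two limits and cannot be read.

Going by these compounds, the amide hydrogen and the aromatic ring leave together, and which of them counts stays open. Cyclohexylamino would keep the amide hydrogen without the aromatic ring, and N-methylbenzylamino would do the reverse.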